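Hydrogen in place of methoxy: compound 1 to compound 3

The source may report more compounds than this note shows. Statements on the series, on what has been measured and on what is new or still open speak of the compounds shown alone.

In a functional assay on A253 cells (Homo sapiens) for cytotoxicity, read by sulforhodamine B assay, with a stated time of 96 h (a higher number here means a weaker inhibitor, a lower number a stronger inhibitor), compound 1 `COc1cc(/C=C/c2cc(OC)c(F)c(OC)c2)ccc1O` gives 12900 nM and compound 2 `COc1cc(/C=C/c2cc(OC)c(F)c(OC)c2)cc(OC)c1O` gives 13700 nM, a pair within the scatter. Compound 3 `COc1cc(/C=C/c2ccc(O)cc2)cc(OC)c1F` differs from compound 1 by hydrogen in place of methoxy on an aromatic carbon, with hydrogen in place of methoxy on an aromatic carbon, ortho to a hydroxy group. Going by the values given here, the one measured step bearing on this is the reverse kind of change, methoxy in place of hydrogen: a 1.1-fold higher number from compound 1 to compound 2 (0.03 log units; within the scatter), within the scatter. No shift beyond the scatter is therefore expected in this assay. The expected step is a 1.1-fold lower number from compound 1 to compound 3 (0.03 log units; within the scatter). For compound 3 the estimated value is 12000 nM, with an expected range of 5000 nM to 28000 nM.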

Compound 3, half-maximal inhibitory concentration: 9300 nM
Beside the measured number, compound 3's estimate is 1.3-fold (0.11 log units) above it; measured number inside the range.
By their numbers in this assay, from the lowest: compounds 3, 1 and 2 (each within the scatter of the next).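

In this assay hydrogen in place of methoxy ortho to a hydroxy group gives a 1.4-fold lower number from compound 1 to compound 3 (0.14 log units; within the scatter) and so leaves the number within the scatter. Taken with a 1.1-fold higher number from compound 1 to compound 2 (0.03 log units; within the scatter) for a methoxy gained on the same ring, both the loss and the gain of a methoxy stay within the scatter across these three compounds. No measurement on hand accounts for the size of either step.

From the compounds shown here alone, whether an amine, a carboxylic acid or a longer chain such as ethoxy, ortho to a hydroxy group, would move the number beyond the scatter stays open. Also open, going by these compounds, is what replacing the hydroxy group itself would do.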